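Swapping Methoxy for Trifluoromethyl on a Channel Opener

The source may hold more compounds than are shown below. What is called first, only, known or untested is meant among the compounds shown, and "the series" means these compounds.

Three related compounds have been measured in an assay on HEK293 cells for activation of Kir3.1/Kir3.2 (Homo sapiens), read by thallium flux; on this read-out higher numbers stand for an effect only at larger amounts of compound and lower numbers for an effect already at smaller amounts. Compound 1 `Cc1cc(NC(=O)Cn2nnc(-c3cccc(F)c3)n2)n(C2CCCCC2)n1` gives 81 nM, compound 2 `COc1ccc(-c2nnn(CC(=O)Nc3cc(C)nn3C3CCCCC3)n2)cc1` gives 175 nM, and compound 3 `COc1cccc(-c2nnn(CC(=O)Nc3cc(C)nn3C3CCCCC3)n2)c1` gives 117 nM. Compound 3 thus stands second highest of the three, with a 1.4-fold higher number from compound 1 to compound 3 (0.16 log units; within the scatter) and a 1.5-fold lower number from compound 2 to compound 3 (0.17 log units; within the scatter) both lying within the scatter, while only a 2.2-fold higher number from compound 1 to compound 2 (0.33 log units; beyond the scatter) reaches beyond it. Compound 4 `Cc1cc(NC(=O)Cn2nnc(-c3cccc(C(F)(F)F)c3)n2)n(C2CCCCC2)n1` differs from compound 3 in one place: trifluoromethyl in place of methoxy on an aromatic carbon, meta to a large group. Within the data shown here, the closest precedent is the exchange at that same position, a 1.4-fold higher number from compound 1 to compound 3 (0.16 log units; within the scatter), which stayed within the scatter, as did the positional shift a 1.5-fold lower number from compound 2 to compound 3 (0.17 log units; within the scatter). Since small changes on this ring left this assay nearly unchanged, no step beyond the scatter is expected for compound 4, a 1.1-fold lower number from compound 3 to compound 4 (0.03 log units; within the scatter). Compound 4 is therefore estimated at 110 nM, within a range of 45 nM to 270 nM.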

Compound 4, half-maximal effective concentration: 183 nM
The estimate for compound 4 lay 1.7-fold (0.22 log units) below the measured number; low and high end bracket the measured number.
By their numbers in this assay, from the lowest: compounds 1, 3, 2 and 4 (each within the scatter of the next, the first and the last beyond it).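

In this assay, the larger trifluoromethyl group gives a 1.6-fold higher number from compound 3 to compound 4 (0.19 log units; within the scatter), a step that stays within the scatter, as does a 1.0-fold higher number from compound 2 to compound 4 (0.02 log units; within the scatter). Against fluoro, however, this position shows its first single-group exchange beyond the scatter, a modest 2.3-fold higher number from compound 1 to compound 4 (0.35 log units; beyond the scatter). Nothing measured here gives a reason for these steps. Open is how an amine or a carboxylic acid at this position would read, since all the groups shown so far on this ring are uncharged.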